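The source may report more compounds than this note shows. Statements on the series, on what has been measured and on what is new or still open speak of the compounds shown alone.

Working notes on the series.

In an ADME assay on MT2 cells (Homo sapiens) for cytotoxicity (on this read-out higher numbers stand for lower toxicity in this test and lower numbers for higher toxicity in this test), compound 2 `CC(C)=CCOc1cc(Nc2nccc(N)n2)ccc1Cl` gives 500 nM, the highest of the two numbers in hand. Among the measured compounds shown here, compound 3 `CC(C)=CCOc1cc(Nc2nccc(CO)n2)ccc1Cl` gives 220 nM in this assay, and the change a 2.3-fold lower number from compound 2 to compound 3 (0.36 log units; beyond the scatter) is the only measured step, a modest one. Compound 1 `CC(C)=CCOc1cc(Nc2ncnc(Cl)n2)ccc1C#N` gives > 100000 nM in this assay, a limit of this assay and not a number. It sits at the limit of > 100000 nM in this assay, at which 1 of the 3 values shown sits, so it cannot be placed against the other two.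

Compound 4 `CC(C)=CCOc1cc(Nc2nccc(N)n2)ccc1C#N` is the next one to be measured in this assay. The change from compound 2 is cyano in place of chloro on an aromatic carbon. For the measured compounds named here, the single measured step concerns the group on the shared core, not the chloro, so it does not bear on this change; compound 1 carries the cyano but differs from compound 4 in a second place as well, and no step between them is available. On this footing no step beyond the scatter is expected in this assay. Compound 4 is expected to give about 700 nM, within 200 nM to 3000 nM, which means an expected step of a 1.4-fold higher number from compound 2 to compound 4 (0.15 log units; within the scatter).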

Compound 4, half-maximal cytotoxic concentration: 41 nM
Beside the measured number, compound 4's estimate is 17-fold (1.23 log units) above it, and the stated range ends above it.
By their numbers in this assay, from the lowest: compound 4; then compound 3; then compound 2. At a limit, above all of these: compound 1.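

In this assay, among the compounds shown here, the aromatic carbon ortho to the (3-methylbut-2-en-1-yl)oxy group proves sensitive to what it carries, which the earlier compounds did not show: cyano in place of chloro there gives a 12-fold lower number from compound 2 to compound 4 (1.09 log units; beyond the scatter). The cyano alone does not produce the low number, since with it held in place, 4-aminopyrimidin-2-yl in place of 4-chloro-1,3,5-triazin-2-yl on the nitrogen gives an at least 2400-fold lower number from compound 1 to compound 4 (3.38 log units; beyond the scatter). That step starts from a limit and not from a number: the limit of > 100000 nM in this assay, at which 1 of the 4 values shown sits.

Nothing shown gives a reason for either step. From the compounds shown here alone, whether fluoro, methyl or a carboxylic acid at this aromatic carbon would give numbers nearer to compound 2 or to compound 4 remains open.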